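A Urea on the Ring Nitrogen of Compound 1

The source may hold more compounds than are shown below. What is called first, only, known or untested is meant among the compounds shown, and "the series" means these compounds.

Compound 1, `NC(=O)c1c(NC(=O)c2ccccc2Cl)sc2c1CCNC2`, gives 18600 nM in a functional assay on HL-60 cells (Homo sapiens) for antiproliferative activity, with a stated time of 24 h; on this read-out lower numbers stand for stronger inhibition and higher numbers for weaker inhibition.
Compound 2, `NC(=O)c1c(NC(=O)c2ccccc2F)sc2c1CCN(Cc1c(Cl)cccc1Cl)C2`, gives 10300 nM in this assay.
Compound 3, `NC(=O)c1c(NC(=O)c2cccc([N+](=O)[O-])c2)sc2c1CCN(Cc1ccc(Cl)cc1Cl)C2`, gives 19800 nM in this assay.

All three compounds share one core, and the number for compound 1 lies within the scatter of both compound 2 and compound 3, so none of the three stands apart from the others. Compound 4, `NC(=O)c1c(NC(=O)c2ccccc2Cl)sc2c1CCN(C(=O)Nc1c(Cl)cccc1Cl)C2`, has not yet been measured. It differs from compound 1 in one place: (2,6-dichlorophenyl)carbamoyl in place of hydrogen on an amine nitrogen in a ring. Among the compounds with values here, no two measured compounds differ in only one place, so no measured step guides this change; compound 2 and compound 3, which also carry a group on the ring nitrogen, give numbers close to that of compound 1. The step of a 1.4-fold lower number from compound 1 to compound 4 (0.16 log units; within the scatter) is expected to stay within the scatter. Compound 4 is estimated at 13000 nM, between 4500 nM and 38000 nM.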

Compound 4, half-maximal inhibitory concentration: 17700 nM
The estimate for compound 4 lay 1.4-fold (0.13 log units) below the measured number, within the range that was stated.
By their numbers in this assay, from the lowest: compounds 2, 4, 1 and 3 (each within the scatter of the next).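

In this assay, within the data shown here, this is the first single change at this ring nitrogen that can be read, and it gives a 1.1-fold lower number from compound 1 to compound 4 (0.02 log units; within the scatter) once the (2,6-dichlorophenyl)carbamoyl group replaces hydrogen. A large group with its own aromatic ring can therefore sit on this amine nitrogen while the number stays within the scatter of compound 1. No measurement shown explains this result.

On these data alone, whether a carboxylic acid, a basic amine or a longer chain at this nitrogen would shift the number beyond the scatter remains open.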